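The compounds below may be only part of what the source reports. "The series", "measured", "known", "first", "only" and "open" are said of these compounds alone.

Compound 1 `CC(C)(C)c1conc1N1C(=O)CSC1c1cccc(C(=O)NCCCCc2ccccc2)c1`: > 1000 nM, a limit and not a number
Compound 2 `O=C(NCCCCc1ccccc1)c1cccc(C2SCC(=O)N2c2ccccc2)c1`: 15.9 nM
Compound 3 `O=C(NCCCCc1ccccc1)c1cccc(C2SCC(=O)N2c2cccc(-c3c[nH]nn3)c2)c1`: 110 nM

These results come from a functional assay on HOS-TE85 cells (Homo sapiens) for inhibition, read by CCK-8 assay, with a stated time of 72 h; on this read-out lower numbers stand for stronger inhibition and higher numbers for weaker inhibition. For the measured compounds named here, only two compounds have true numbers, and compound 3 has the higher of them, at 110 nM. Compound 2 has the nearest value, at 15.9 nM. Compound 1 is reported only as a limit, > 1000 nM.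

Compound 4 `COc1cccc(OC)c1N1C(=O)CSC1c1cccc(C(=O)NCCCCc2ccccc2)c1` is still unmeasured. It changes the group on an amide-type nitrogen in a ring, and 2,6-dimethoxyphenyl enters there: a group of 10 heavy atoms (8 carbon, 2 oxygen; one six-membered aromatic ring of carbon only) in place of a group of 11 heavy atoms (8 carbon, 3 nitrogen; one five-membered aromatic ring with 3 hetero atoms, one six-membered aromatic ring of carbon only), on an amide-type nitrogen in a ring.

The measured steps show that this site matters. The change at this nitrogen gave an at least 62-fold lower number from compound 1 to compound 2 (1.79 log units; beyond the scatter), and a second change there gave an at least 9.0-fold lower number from compound 1 to compound 3 (0.95 log units; beyond the scatter). Adding the triazolyl group to the plain phenyl ring gave a 6.9-fold higher number from compound 2 to compound 3 (0.84 log units; beyond the scatter). Among these three compounds, both groups other than plain phenyl give weaker results than compound 2, with no compound going against this. Compound 4 also carries a substituted phenyl ring, so it is expected to sit near compound 3 rather than near compound 2, though the evidence is thin. The expected change is a 1.4-fold higher number from compound 3 to compound 4 (0.13 log units; within the scatter), which amounts to no clear step beyond the scatter. For compound 4 the estimated value is 150 nM, with an expected range from 30 nM to 800 nM.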

Compound 4, half-maximal inhibitory concentration: > 1000 nM
Compound 4: no number, only a limit (the forecaster's own chance of this, stated with the estimate: 15%); at least 6.6-fold (0.82 log units) between middle value and limit.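

In this assay, putting 2,6-dimethoxyphenyl in place of phenyl on the amide-type nitrogen in the ring gives an at least 62-fold higher number from compound 2 to compound 4 (1.79 log units; beyond the scatter), so the earlier drop from adding a group to this phenyl ring is not the largest seen here. The same position also separates two substituted phenyl rings, with the change to 2,6-dimethoxyphenyl from the triazolyl-bearing ring giving an at least 9.0-fold higher number from compound 3 to compound 4 (0.95 log units; beyond the scatter), which shows that having a substituted phenyl ring at this nitrogen does not by itself set the result; what the ring carries matters. Compound 4 is reported only as a limit, and so is compound 1, so the step between these two cannot be read, and their isoxazole-bearing and dimethoxyphenyl groups cannot be ranked against each other: the limit of > 1000 nM in this assay, at which 2 of the 4 values shown sit.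

The compounds shown leave open whether a phenyl ring carrying a single methoxy group, a fluorine atom or a methyl group would stay close to compound 2 or fall away as compound 4 does. They also leave open whether an amine or a carboxylic acid on this ring could match or improve on plain phenyl.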